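A few compounds are considered here, and "the series" means these few. Any claim that something is new, unique, unknown or untested is made for them only; others in the source may bear on it.

Measured so far in an assay on RBL-1 cells for inhibition of Polyunsaturated fatty acid 5-lipoxygenase (Rattus norvegicus); a higher number here means a weaker inhibitor, a lower number a stronger inhibitor:
compound 1 `Cc1cccc(N2CC(C)NC(=O)N2)n1` gives 3800 nM
compound 2 `CC1CN(c2cccc(Cl)n2)NC(=O)N1` gives 3500 nM

Within the data shown here, compound 2 stands beside compound 1 rather than apart from it: the only step between them, a 1.1-fold lower number from compound 1 to compound 2 (0.04 log units; within the scatter), lies within the scatter, so on these two numbers neither compound can be called the stronger inhibitor in this assay.

Compound 3 `CC1CN(c2cccc(Br)n2)NC(=O)N1` differs from compound 2 in a single place: bromo in place of chloro on an aromatic carbon. Among the measured compounds shown here, the one measured step that bears on this change is the swap at the same place from compound 1 to compound 2, a 1.1-fold lower number from compound 1 to compound 2 (0.04 log units; within the scatter), in which a methyl gave way to a chloro and the number stayed within the scatter. For the measured compounds named here, that is the whole of the evidence; there is no measured pair in which a bromo replaces a chloro. On this basis the step from compound 2 to compound 3 in this assay is expected to be no change at the digits printed from compound 2 to compound 3 (within the scatter), that is, nothing beyond the scatter in either direction. Compound 3 is therefore estimated at 3500 nM, with a range from 1500 nM to 8000 nM.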

Compound 3, half-maximal inhibitory concentration: 2400 nM
Compound 3: middle estimate off by 1.5-fold (0.16 log units), on the high side; measured number inside the range.
By their numbers in this assay, from the lowest: compounds 3, 2 and 1 (each within the scatter of the next).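

In this assay, the place on the aromatic ring next to the ring nitrogen has now carried a methyl, a chloro and a bromo, and the new comparisons, a 1.5-fold lower number from compound 2 to compound 3 (0.16 log units; within the scatter) and a 1.6-fold lower number from compound 1 to compound 3 (0.20 log units; within the scatter), both stay within the scatter, as the earlier swap did. The earlier compounds offered only one exchange at this place, whereas there are now three pairs, and none of them separates one group from another, so no group among these three can be called the better one here. Nothing measured alongside these numbers speaks to what lies behind this result.

What the compounds shown leave open is whether this place would respond to a group of a very different kind, such as an amine, a carboxylic acid or a longer chain, as all the readings so far come from a methyl and two halogens. Among these compounds, it also remains open whether swapping a chloro for a bromo would read the same way on any core other than the one shared by these compounds.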